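The source may report more compounds than this note shows. Statements on the series, on what has been measured and on what is new or still open speak of the compounds shown alone.

Compound 1, `Fc1cccc(-c2nc(Nc3ccccc3Cl)c3cc(F)ccc3n2)c1`, gives > 50000 nM in a functional assay on COLO 205 cells (Homo sapiens) for cytotoxicity, read by MTT assay, with a stated time of 48 h (a lower number here means a stronger inhibitor, a higher number a weaker inhibitor), which is a limit of this assay.
Compound 2, `Fc1cccc(-c2nc(Nc3cccc(Br)c3)c3cc(F)ccc3n2)c1`, gives > 50000 nM in this assay, also a limit.
Compound 3, `Oc1cccc(Nc2nc(-c3cccc(F)c3)nc3ccc(F)cc23)c1`, gives > 50000 nM in this assay, again a limit.

Compound 3 thus stands where the other two stand, at the limit of > 50000 nM in this assay, at which 3 of the 3 values shown sit. The steps a step that the two limits leave unreadable from compound 1 to compound 3, a step that the two limits leave unreadable from compound 2 to compound 3 and a step that the two limits leave unreadable from compound 1 to compound 2 are all unreadable, both ends of each sitting at that limit. The change leading to compound 4, `Nc1cccc(Nc2nc(-c3cccc(F)c3)nc3ccc(F)cc23)c1`, is amino in place of hydroxy on an aromatic carbon. Among the measured compounds shown here, no measured step on that ring has a readable size, so the expectation for this assay rests on the limit alone. Compound 4 is expected to remain at the limit, at about 50000 nM, within 20000 nM to 120000 nM. The expected step is a number no higher from compound 3 to compound 4 (the limit leaves the size open), none beyond the scatter.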

Compound 4, half-maximal inhibitory concentration: > 50000 nM
Compound 4 ended at the assay's limit (the forecaster's own chance of this, stated with the estimate: 80%); the middle value sits exactly at the limit.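

In this assay, among the compounds shown here, compound 4 sits at the same limit as compound 1, compound 2 and compound 3, and no step among them can be read. The compounds shown leave open whether the amino, hydroxy, bromo and chloro compounds differ at all, and what true value any of them has.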